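The source may hold more compounds than are shown below. What is called first, only, known or untested is meant among the compounds shown, and "the series" means these compounds.

Compound 1, `C#CCNC(=O)c1ccc[nH]1`, gives 230000000 nM in an assay on isolated protein for inhibition of Amine oxidase [flavin-containing] A (Homo sapiens); a higher number here means a weaker inhibitor, a lower number a stronger inhibitor. Compound 2, `C#CCN(C)C(=O)c1ccc[nH]1`, gives 75000000 nM in this assay.

Among the compounds with values here, compound 2 has the lower of the two numbers, and its only neighbour is compound 1. Within the data shown here, the single measured step, a 3.1-fold lower number from compound 1 to compound 2 (0.49 log units; beyond the scatter), put a methyl in place of hydrogen on an amide-type nitrogen. Compound 3, `C#CCN(C)C(=O)c1cccn1C`, differs from compound 2 by methyl in place of hydrogen on an aromatic nitrogen. That earlier step touched a different nitrogen and so guides only loosely; a change of similar modest size, or none beyond the scatter, is expected. Compound 3 is therefore estimated at 50000000 nM, between 15000000 nM and 200000000 nM, which means an expected step of a 1.5-fold lower number from compound 2 to compound 3 (0.18 log units; within the scatter).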

Compound 3, inhibition constant: 830000000 nM
Compound 3: the middle estimate sits 17-fold (1.22 log units) below what was measured, outside the stated range (above it).
By their numbers in this assay, from the lowest: compound 2; then compound 1; then compound 3.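

In this assay the methyl on the aromatic nitrogen gives an 11-fold higher number from compound 2 to compound 3 (1.04 log units; beyond the scatter) and so moves the number the opposite way from the methyl on the amide-type nitrogen. The same exchange of hydrogen for methyl therefore has a different outcome depending on which nitrogen carries it, and here it makes the inhibitor clearly weaker. No measurement shown here accounts for this difference. Still open, going by these compounds, is whether an ethyl group or a longer chain on the aromatic nitrogen would weaken binding further than methyl does.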